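The source may report more compounds than this note shows. Statements on the series, on what has been measured and on what is new or still open speak of the compounds shown alone.

Three compounds of this series carry a measurement in a functional assay on HUVEC cells (Homo sapiens), read by scintillation counting and thymidine incorporation, with a stated time of 24 h (on this read-out lower numbers stand for stronger inhibition and higher numbers for weaker inhibition), and a fourth is still to be measured there.

Compound 1 `CCC(C)n1ncn(-c2ccc(N3CCN(c4ccc(OC[C@@H]5COC(c6ccc(Cl)cc6Cl)O5)cc4)CC3)cc2)c1=O` gives 328 nM. Compound 2 `CCC(C)n1ncn(-c2ccc(N3CCN(c4ccc(OC[C@@H]5CO[C@@](CC6CCCC6)(c6ccc(Cl)cc6Cl)O5)cc4)CC3)cc2)c1=O` gives 512 nM. Compound 3 `CCC(C)n1ncn(-c2ccc(N3CCN(c4ccc(OC[C@@H]5CO[C@@](Cc6ccccc6)(c6ccc(Cl)cc6Cl)O5)cc4)CC3)cc2)c1=O` gives 513 nM. Among the compounds with values here, the step of a 1.0-fold higher number from compound 2 to compound 3 (0.00 log units; within the scatter) is the one measured pair that differs in a single place. Compound 3 thus has the highest of the three numbers, but its gap to compound 2 and its gap to compound 1 both lie within the scatter, so no order among the three can be read from these values.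

Compound 4 `CCC(C)n1ncn(-c2ccc(N3CCN(c4ccc(OC[C@@H]5CO[C@@](CN6CCN(C)CC6)(c6ccc(Cl)cc6Cl)O5)cc4)CC3)cc2)c1=O` differs from compound 3 by 4-methylpiperazin-1-yl in place of phenyl on a saturated chain carbon bound to a saturated ring carbon. Within the data shown here, the only measured step at this place, from compound 2 to compound 3, exchanged one carbon ring for another and left the number unchanged. Among the measured compounds shown here, the present change brings a ring with two hetero atoms and two hydrogen-bond acceptors in place of an aromatic carbon ring; no measured pair covers a change of this kind, so the expectation rests on the flatness seen so far at this place.

The step from compound 3 to compound 4 is expected to be a 1.1-fold higher number from compound 3 to compound 4 (0.03 log units; within the scatter), with no direction claimed beyond the scatter. Compound 4 is therefore estimated at 550 nM, within a range of 200 nM to 1500 nM.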

Compound 4, half-maximal inhibitory concentration: 396 nM
For compound 4 the middle estimate is 1.4-fold (0.14 log units) above the measured one, and the stated range covers the measured number.
By their numbers in this assay, from the lowest: compounds 1, 4, 2 and 3 (each within the scatter of the next).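

In this assay, 4-methylpiperazin-1-yl in place of phenyl on a saturated chain carbon bound to a saturated ring carbon gives a 1.3-fold lower number from compound 3 to compound 4 (0.11 log units; within the scatter), and 4-methylpiperazin-1-yl in place of cyclopentyl at the same place gives a 1.3-fold lower number from compound 2 to compound 4 (0.11 log units; within the scatter). Until now, only carbon rings had been compared at this place, so the flat result could have been limited to that kind of group; it now extends to a non-aromatic ring with 2 hetero atoms and 2 hydrogen-bond acceptors, since neither step lies beyond the scatter. Nothing at hand accounts for this insensitivity of the read-out to the exchange.

The compounds shown leave open whether the number would also stay flat with an open-chain amine such as dimethylamino, with a carboxylic acid, or with morpholin-4-yl at this place. They also leave open whether a longer chain between the ring carbon and the terminal ring would move the number beyond the scatter, and whether the flatness at this place holds on a different core.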